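This account rests on a few compounds, and the source may have more. Where it says the series, first, only, none or still open, it means among the compounds named here.

Compounds measured so far in a functional assay on HCT-116 cells (Homo sapiens) for antiproliferative activity, read by MTT assay, with a stated time of 72 h; on this read-out higher numbers stand for weaker inhibition and lower numbers for stronger inhibition:
- compound 1, `O=C(O)CCc1cccc2c1B(O)OC2`, gives only a limit of the assay, > 100000 nM
- compound 2, `O=C(CCc1cccc2c1B(O)OC2)Nc1ccccc1`, gives 350 nM
- compound 3, `CC(C)(C)c1ccc(NC(=O)CCc2cccc3c2B(O)OC3)cc1`, gives 19000 nM

Compound 2 stands at the lowest number among the two numbers in this assay, with compound 3 as its nearest neighbour at a 54-fold higher number from compound 2 to compound 3 (1.73 log units; beyond the scatter). For compound 1 the value is a limit only (the limit of > 100000 nM in this assay, at which 1 of the 3 values shown sits).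

The next compound, compound 4, `N#Cc1ccc(-c2cccc(NC(=O)CCc3cccc4c3B(O)OC4)c2)cc1`, is to be measured in this assay. Its change from compound 2 is 4-cyanophenyl in place of hydrogen on an aromatic carbon.

Within the data shown here, two measured steps bear on this one. The step of an at least 280-fold lower number from compound 1 to compound 2 (2.45 log units; beyond the scatter) shows that the anilino group itself carries most of the activity of compound 2. The step of a 54-fold higher number from compound 2 to compound 3 (1.73 log units; beyond the scatter) shows that a substituent placed on the anilino ring, there tert-butyl, gives a large move toward weaker inhibition. Among the measured compounds shown here, compound 4 again puts a group on that ring, a 4-cyanophenyl, at a different place and of a different kind, so the size of the effect is uncertain, but the direction seen in compound 3 is the only guide. A step toward weaker inhibition beyond the scatter is therefore expected, an 8.6-fold higher number from compound 2 to compound 4 (0.93 log units; beyond the scatter).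

Compound 4 is estimated in this assay at 3000 nM, within 300 nM to 30000 nM.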

Compound 4, half-maximal inhibitory concentration: 410 nM
Estimate against measurement, compound 4: 7.3-fold (0.86 log units) above; the measured number falls inside the stated range.
By their numbers in this assay, from the lowest: compounds 2 and 4 (each within the scatter of the next); then compound 3. At a limit, above all of these: compound 1.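

In this assay, a 4-cyanophenyl on an aromatic carbon of the anilino ring, meta to a large group, gives a number that cannot be told apart from that of the unsubstituted anilide: a 1.2-fold higher number from compound 2 to compound 4 (0.07 log units; within the scatter). This ring therefore accepts a group of 8 heavy atoms, with a further aromatic ring and a nitrile, at no measurable cost, so a substituent here does not by itself weaken inhibition, and compound 3 goes against any such reading with a 54-fold higher number from compound 2 to compound 3 (1.73 log units; beyond the scatter). No measured property in the data on this series accounts for this result.

Compound 3 and compound 4 differ in both the group and its place on the ring, so the compounds shown leave open whether the place or the kind of group separates their numbers. Also open, going by these compounds, are whether the nitrile contributes anything, which an unsubstituted phenyl at the same carbon would test, and how a tert-butyl at that carbon, an amine on the anilino ring or a longer chain to the amide carbonyl would read in this assay.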